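From Pyridin-3-yl to Pyridin-4-yl on a Shared Core

The source may hold more compounds than are shown below. What is called first, only, known or untested is meant among the compounds shown, and "the series" means these compounds.

Three related compounds have been measured in a functional assay on CNS cells (Homo sapiens) for antiproliferative activity; a lower number here means a stronger inhibitor of growth, a higher number a weaker inhibitor of growth. Compound 1 (`Cc1cn2c(/C=N/NC(=N)N)c(-c3ccncc3)nc2s1`) gives 16200 nM, compound 2 (`N=C(N)N/N=C/c1c(-c2ccccn2)nc2sc(Cl)cn12`) gives 5620 nM, and compound 3 (`N=C(N)N/N=C/c1c(-c2cccnc2)nc2sc(Cl)cn12`) gives 15100 nM. Compound 3 therefore sits within the scatter of compound 1 and is a weaker inhibitor than compound 2.

The next compound, compound 4 (`N=C(N)N/N=C/c1c(-c2ccncc2)nc2sc(Cl)cn12`), has pyridin-4-yl in place of pyridin-3-yl on an aromatic carbon. For the measured compounds named here, the only measured step at this carbon is a 2.7-fold higher number from compound 2 to compound 3 (0.43 log units; beyond the scatter), a modest change that came from swapping pyridin-2-yl for pyridin-3-yl. It involves a different swap, so it offers only a rough guide to size. Compound 1 also carries pyridin-4-yl, though its core differs elsewhere, and it gives 16200 nM. No step beyond the scatter is therefore expected in this assay. The expected change is a 1.1-fold lower number from compound 3 to compound 4 (0.03 log units; within the scatter). Compound 4 is estimated at 14000 nM, with an expected range of 6500 nM to 28000 nM.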

Compound 4, concentration for 50% growth inhibition: 7760 nM
Estimate against measurement, compound 4: 1.8-fold (0.26 log units) above; low and high end bracket the measured number.
By their numbers in this assay, from the lowest: compounds 2, 4, 3 and 1 (each within the scatter of the next, the first and the last beyond it).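

In this assay pyridin-4-yl in place of pyridin-3-yl (a 1.9-fold lower number from compound 3 to compound 4 (0.29 log units; within the scatter)) and pyridin-4-yl in place of pyridin-2-yl (a 1.4-fold higher number from compound 2 to compound 4 (0.14 log units; within the scatter)) both stay within the scatter. The pyridin-4-yl compound therefore cannot be told apart from either of the other two pyridine compounds on the shared core, even though those two differ from each other beyond the scatter. For the compounds shown here, with pyridin-4-yl held constant, chloro in place of methyl on an aromatic carbon (a 2.1-fold lower number from compound 1 to compound 4 (0.32 log units; beyond the scatter)) gives the first measured step at another place on the core, and that modest step lies beyond the scatter.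

Going by these compounds, what a plain phenyl ring at the pyridine carbon, or bromo in place of chloro, would do remains open. Nothing shown here bears on what lies behind these numbers.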